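Swapping Trifluoromethyl for Methyl on a Weak Inhibitor

The source may hold more compounds than are shown below. What is called first, only, known or untested is meant among the compounds shown, and "the series" means these compounds.

Of the compounds shown here, two built on one shared core have been tested in a functional assay on a subcellular fraction from brain (Rattus norvegicus) for inhibition, read by scintillation counting, with a stated time of 5 min; on this read-out lower numbers stand for stronger inhibition and higher numbers for weaker inhibition. Compound 1 `FC(F)(F)c1ccc(NC2=NCCC3(CCCCC3)S2)cc1` carries a trifluoromethyl on its outer aromatic ring, and in this assay compound 1 gives 77600 nM, the higher of the two numbers seen so far, which places it at the weaker end. Compound 2 `Clc1ccc(NC2=NCCC3(CCCCC3)S2)cc1` carries chloro at that spot instead, and in this assay compound 2 gives 35500 nM. Among the compounds with values here, the only measured step is a 2.2-fold lower number from compound 1 to compound 2 (0.34 log units; beyond the scatter).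

Compound 3 `Cc1ccc(NC2=NCCC3(CCCCC3)S2)cc1` has not yet been measured. It differs from compound 1 by methyl in place of trifluoromethyl on an aromatic carbon. Within the data shown here, no measured step involves methyl directly, so the closest guide is the exchange of trifluoromethyl for another small group, a 2.2-fold lower number from compound 1 to compound 2 (0.34 log units; beyond the scatter), which lowered the number modestly. On that basis the change to compound 3 is expected to be of a similar modest size and in the same direction, though a result within the scatter is also plausible. The expected step is a 1.9-fold lower number from compound 1 to compound 3 (0.29 log units; within the scatter). Compound 3 is therefore estimated to give about 40000 nM in this assay, within a range from 15000 nM to 120000 nM.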

Compound 3, half-maximal inhibitory concentration: 31600 nM
Compound 3: the middle estimate sits 1.3-fold (0.10 log units) above what was measured; low and high end bracket the measured number.
By their numbers in this assay, from the lowest: compounds 3 and 2 (each within the scatter of the next); then compound 1.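

In this assay, methyl in place of trifluoromethyl gives a 2.5-fold lower number from compound 1 to compound 3 (0.39 log units; beyond the scatter), so a second replacement at this spot on the outer aromatic ring moves the number in the same direction as chloro did, and the earlier step no longer stands alone. Methyl and chloro cannot be told apart here, with a 1.1-fold lower number from compound 2 to compound 3 (0.05 log units; within the scatter), so compound 1 stands alone at the higher number, while compound 2 and compound 3 sit together, with compound 3 at 31600 nM, and neither replacement brings a large change. Nothing measured here explains why trifluoromethyl differs from the other two groups in this series.

The compounds shown leave open how far this spot can be pushed, since all three groups are small and uncharged, and a plain hydrogen, an amine, a carboxylic acid or a longer chain such as butyl could give a very different number or much the same one. They also leave open whether the small step seen with methyl and chloro would carry over to a different shared core.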